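A Side-Chain Exchange in a Tight Group of Values

The compounds below may be only part of what the source reports. "The series", "measured", "known", "first", "only" and "open" are said of these compounds alone.

In a functional assay on HepG2 cells (Homo sapiens) for inhibition, read by MTT assay, with a stated time of 3 days (a higher number here means a weaker inhibitor, a lower number a stronger inhibitor), compound 1 (`COc1cc(-c2nc3ccccc3s2)ccc1OCC(=O)NNC(O)CN(C)CC(=O)O`) gives 3030 nM and compound 3 (`COc1cc(-c2nc3ccccc3s2)ccc1OCC(=O)NNC(=O)CNC(=N)NCCC[C@H](N[N+](=O)[O-])C(=O)O`) gives 3490 nM on the same core. Compound 2 (`COc1cc(-c2nc3ccccc3s2)ccc1OCC(=O)NNC(=O)CN(C(C)=O)[C@@H](CS)C(=O)O`) gives 3420 nM and lies within the scatter of both. The change (1-(ethoxycarbonyl)-2-methylbutyl)amino in place of acetyl(1-carboxy-2-sulfanylethyl)amino on a saturated chain carbon bound to a carbonyl carbon leads to compound 4 (`CCOC(=O)[C@@H](NCC(=O)NNC(=O)COc1ccc(-c2nc3ccccc3s2)cc1OC)[C@@H](C)CC`), not yet measured, with (1-(ethoxycarbonyl)-2-methylbutyl)amino in place of acetyl(1-carboxy-2-sulfanylethyl)amino on a saturated chain carbon bound to a carbonyl carbon. Among the measured compounds shown here, no measured step isolates this change, but the differing side chains of compound 1 at 3030 nM and compound 2 at 3420 nM stay within the scatter. The estimated step of a 1.1-fold lower number from compound 2 to compound 4 (0.03 log units; within the scatter) is therefore expected to show no direction beyond the scatter in this assay when measured. Compound 4 is expected at 3200 nM with an estimated range from 1300 nM to 8000 nM in this test.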

Compound 4, half-maximal inhibitory concentration: 3460 nM
The estimate for compound 4 lay 1.1-fold (0.03 log units) below the measured number, and the stated range covers the measured number.
By their numbers in this assay, from the lowest: compounds 1, 2, 4 and 3 (each within the scatter of the next).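

In this assay, this position now has its first directly measured step, a 1.0-fold higher number from compound 2 to compound 4 (0.01 log units; within the scatter), and it lies within the scatter. On a saturated chain carbon bound to a carbonyl carbon, (1-(ethoxycarbonyl)-2-methylbutyl)amino and acetyl(1-carboxy-2-sulfanylethyl)amino cannot be told apart, even though the two groups differ in their atoms and defined stereocentres. Nothing shown accounts for this result. The compounds shown leave open whether a simple primary amine or a phenyl ring at this place would give a value beyond the scatter of this tight group.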